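This account rests on a few compounds, and the source may have more. Where it says the series, first, only, none or still open, it means among the compounds named here.

Working notes on the series. Compound 1 `O=C(CNc1ccc(F)cc1)Nc1nc2ccc(Cl)cc2s1` gives in a functional assay on the whole organism with Mus musculus as the target, with a stated time of 0.5 h (on this read-out higher numbers stand for an effect only at larger amounts of compound and lower numbers for an effect already at smaller amounts), a minimum effective dose of 100 mg/kg. Compound 2 `CC(C)(C)NCC(=O)Nc1nc2ccc(Cl)cc2s1` gives in this assay a minimum effective dose of 100 mg/kg. The one measured step, tert-butyl in place of 4-fluorophenyl on an amine nitrogen, reads no change at the digits printed from compound 1 to compound 2 (within the scatter), so compound 2 stands level with compound 1 at the digits shown and no ordering between the two can be claimed.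

Compound 3 `O=C(Cn1ccnc1)Nc1nc2ccc(Cl)cc2s1` is not yet measured in this assay. Its change from compound 2 is 1H-imidazol-1-yl in place of (tert-butyl)amino on a saturated chain carbon bound to a carbonyl carbon. Within the data shown here, no measured step bears directly on it: the amine nitrogen that survived the step from compound 1 to compound 2 is removed here, and the series holds no pair in which an amine is exchanged for an aromatic ring. Among the measured compounds shown here, the only step known, no change at the digits printed from compound 1 to compound 2 (within the scatter), shows the read-out unmoved by a change at this part of the chain, which is the sole ground for the expectation below.

The step from compound 2 to compound 3 is therefore expected to be no change at the digits printed from compound 2 to compound 3 (within the scatter), none beyond the scatter. Compound 3 is expected to give 100 mg/kg in this assay, within 40 mg/kg to 250 mg/kg.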

Compound 3, minimum effective dose: 100 mg/kg
For compound 3 middle estimate and measured number coincide at the digits printed; the measured number falls inside the stated range.
By their numbers in this assay, from the lowest: compounds 1, 2 and 3 (each within the scatter of the next).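

In this assay, the exchange of (tert-butyl)amino for 1H-imidazol-1-yl on a saturated chain carbon bound to a carbonyl carbon reads no change at the digits printed from compound 2 to compound 3 (within the scatter) and so extends the flat picture to a different kind of group. Unlike the earlier step, no change at the digits printed from compound 1 to compound 2 (within the scatter) where an amine nitrogen stayed in place, this one removes that nitrogen and its hydrogen-bond donor and brings in a five-membered aromatic ring with 2 hetero atoms and 0 hydrogen-bond donors, yet the read-out does not separate the two compounds. No measurement at hand accounts for this flat read-out.

From the compounds shown here alone, all three compounds lie within the scatter of one another, so it remains open whether any group on this chain carbon can move the read-out at all, for example a carboxylic acid or a longer chain ending in the same 1H-imidazol-1-yl. The compounds also share one core, which leaves open what replacing its chlorine with a methoxy group would do to the minimum effective dose.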